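The source may hold more compounds than are shown below. What is called first, only, known or untested is meant among the compounds shown, and "the series" means these compounds.

Measured so far in a functional assay on RAW264.7 cells (Mus musculus) for inhibition, read by ELISA, with a stated time of 24 h; on this read-out lower numbers stand for an effect already at smaller amounts and higher numbers for an effect only at larger amounts of compound:
- compound 1 `CC/C=C\C[C@H]1C(=O)C=C[C@H]1CC(=O)OCCC`: 23000 nM
- compound 2 `CC/C=C\C[C@H]1C(=O)C=C[C@H]1CC(=O)OCCCC`: 23000 nM
- compound 3 `CC/C=C\C[C@H]1C(=O)C=C[C@H]1CC(=O)OCCOCCOC`: 33000 nM

Compound 3, at 33000 nM, lies within the scatter of both other compounds, so the three values do not separate.

The next compound is compound 4 `CC/C=C\C[C@H]1C(=O)C=C[C@H]1CC(=O)OC(C)C`. The change is isopropyl in place of 2-(2-methoxyethoxy)ethyl on an oxygen next to a carbonyl group, with isopropyl in place of 2-(2-methoxyethoxy)ethyl on an oxygen next to a carbonyl group.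

Going by the values given here, three measured steps bear on this change, all made in the same chain: no change at the digits printed from compound 1 to compound 2 (within the scatter), a 1.4-fold higher number from compound 1 to compound 3 (0.16 log units; within the scatter) and a 1.4-fold higher number from compound 2 to compound 3 (0.16 log units; within the scatter). None of them leaves the scatter. Among the compounds with values here, no measured compound carries isopropyl, so a direct comparison is missing and the expectation rests on these small steps alone.

No step beyond the scatter is expected in this assay, in either direction. The expected step is a 1.3-fold lower number from compound 3 to compound 4 (0.12 log units; within the scatter).

For compound 4 the estimate is 25000 nM, with an expected range of 13000 nM to 50000 nM.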

Compound 4, half-maximal effective concentration: 20000 nM
Estimate against measurement, compound 4: 1.3-fold (0.10 log units) above; low and high end bracket the measured number.
By their numbers in this assay, from the lowest: compounds 4, 1, 2 and 3 (each within the scatter of the next).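

In this assay isopropyl on an oxygen next to a carbonyl group gives a 1.7-fold lower number from compound 3 to compound 4 (0.22 log units; within the scatter), so even this exchange for 2-(2-methoxyethoxy)ethyl, which removes both hydrogen-bond acceptors of the leaving group, does not separate the two compounds. Against the unbranched groups the steps are a 1.2-fold lower number from compound 2 to compound 4 (0.06 log units; within the scatter) for butyl and a 1.2-fold lower number from compound 1 to compound 4 (0.06 log units; within the scatter) for propyl, so isopropyl, the only branched group here, also stays level with both. No evidence on the cause of these small steps accompanies the values. Still open, on these data alone, is whether any group on this oxygen can move the number beyond the scatter. The carboxylic acid, a 2-aminoethyl group or a longer chain such as octyl would test that, and all four compounds shown leave the shared core unchanged.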